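The compounds below may be only part of what the source reports. "The series", "measured", "known", "first", "only" and "open" are said of these compounds alone.

Measured so far, in a functional assay on the whole organism with Rattus norvegicus as the target, at a dose of 100 mg/kg; a higher number here means more inhibition at the dose given (going by the name of the read-out), a lower number less inhibition:

Compound 1, `C/N=C(\S)NCCCCCn1nc(-c2ccccc2)ccc1=O`: 68.9%
Compound 2, `C/N=C(\S)NCCCCCCn1nc(-c2ccccc2)ccc1=O`: 22.2%

Among the compounds with values here, compound 2 stands at the bottom of these two numbers; its only neighbour is compound 1, and the step of a number 46.7 percentage points lower from compound 1 to compound 2 (beyond the scatter) is a large drop, well beyond the usual scatter. That step swapped one chain end for a slightly longer one, at a place five bonds along the chain from an aromatic nitrogen.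

Compound 3, `CN(C)/C(=N/CCCCCn1nc(-c2ccccc2)ccc1=O)NC#N`, has not been measured. It differs from compound 2 by a group of 8 heavy atoms (4 carbon, 4 nitrogen; no ring) in place of a group of 6 heavy atoms (3 carbon, 2 nitrogen, 1 sulfur; no ring), on a saturated chain carbon, five bonds along the chain from an aromatic nitrogen. The group that leaves here is the very group that entered in the step from compound 1 to compound 2, so that step is the only one that bears on this change, and it was large. Within the data shown here, what enters, though, is a group of a different kind, with no measured counterpart, so there is no direct guide to its effect.

Taking the large size of a number 46.7 percentage points lower from compound 1 to compound 2 (beyond the scatter) as the scale for changes at this place, compound 3 is expected to move upward by about a number 27.8 percentage points higher from compound 2 to compound 3 (beyond the scatter), with wide uncertainty. The estimate for compound 3 in this assay is 50%, ranging from 15% to 80%.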

Compound 3, a percentage reported as inhibition, in the whole organism at one dose (the size of the read-out at that dose, not a potency): 63.9%
Compound 3: middle estimate off by 13.9 percentage points, on the low side, and the stated range covers the measured number.
By their numbers in this assay, from the lowest: compound 2; then compounds 3 and 1 (each within the scatter of the next).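

Against compound 2, the group of 8 heavy atoms (4 carbon, 4 nitrogen) gives a number 41.7 percentage points higher from compound 2 to compound 3 (beyond the scatter) in this assay, so the low number of compound 2 is not fixed for every group at this place. Against compound 1, the same group gives a number 5 percentage points lower from compound 1 to compound 3 (within the scatter), which shows that sulfur is not needed here to keep inhibition at this level at this dose, and that a group with a nitrile can stand in for the sulfur-bearing one. No measurement among these data accounts for the differences between these three compounds.

Going by these compounds, it remains open which part of the entering group matters, for instance whether a plain guanidine or a urea, neither carrying the nitrile, would reach the same level at this place. It is also open whether a longer chain ending in the nitrile-bearing group would lose inhibition as compound 2 does, and, with only one dose shown, whether the same picture would hold at other doses.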